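The source may hold more compounds than are shown below. What is called first, only, known or untested is meant among the compounds shown, and "the series" means these compounds.

Of the compounds shown here, three built on the same core have been measured in an assay on HeLa cells for displacement of a labelled ligand from adenosine receptor A3 (Homo sapiens), read by fluorescence polarization, with a stated time of 30 min; on this read-out higher numbers stand for weaker inhibition and lower numbers for stronger inhibition. Compound 1 `COc1ccc(-c2cc(NC(=O)COCC(=O)NCC(=O)NC(C)(C)C)nc(-c3ccc(OC)cc3)n2)cc1` gives 11200 nM. Compound 2 `COc1ccc(-c2cc(NC(=O)COCC(=O)NCC(=O)NCc3ccccc3)nc(-c3ccc(OC)cc3)n2)cc1` gives 64600 nM, and compound 3 `COc1ccc(-c2cc(NC(=O)COCC(=O)N(C)CC(=O)NC(C)(C)C)nc(-c3ccc(OC)cc3)n2)cc1` gives 7200 nM. Compound 3 thus carries the lowest of the three numbers, although its gap to compound 1 is within the scatter, while its gap to compound 2, a 9.0-fold lower number from compound 2 to compound 3 (0.95 log units; beyond the scatter), is beyond it. The step of a 1.6-fold lower number from compound 1 to compound 3 (0.19 log units; within the scatter) shows that the methyl on the amide-type nitrogen by itself changes little.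

Compound 4 `COc1ccc(-c2cc(NC(=O)COCC(=O)N(C)CC(=O)NCc3ccccc3)nc(-c3ccc(OC)cc3)n2)cc1` has not yet been measured in this assay. It differs from compound 3 in one place: benzyl in place of tert-butyl on an amide-type nitrogen. The same exchange has already been seen once, in the pair without the methyl, where a 5.8-fold higher number from compound 1 to compound 2 (0.76 log units; beyond the scatter) was found, a step beyond the scatter. Nothing among the three measured compounds suggests that the methyl on the amide-type nitrogen would alter the effect of this exchange.

Compound 4 is therefore expected to give a higher number than compound 3, with a step of about a 5.0-fold higher number from compound 3 to compound 4 (0.70 log units; beyond the scatter). The estimate for compound 4 in this assay is 36000 nM, within a range from 15000 nM to 90000 nM.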

Compound 4, inhibition constant: 19000 nM
For compound 4 the middle estimate is 1.9-fold (0.28 log units) above the measured one; low and high end bracket the measured number.
By their numbers in this assay, from the lowest: compounds 3, 1 and 4 (each within the scatter of the next, the first and the last beyond it); then compound 2.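

With compound 4, the exchange of tert-butyl for benzyl on an amide-type nitrogen can be read both with and without the methyl, and in this assay it raises the number both times, here with a 2.6-fold higher number from compound 3 to compound 4 (0.42 log units; beyond the scatter), the two steps agreeing within what two such steps allow: the same change on two cores in this assay, a 5.8-fold higher number (0.76 log units; beyond the scatter) from compound 1 to compound 2 and a 2.6-fold higher number (0.42 log units; beyond the scatter) from compound 3 to compound 4, 2.2-fold (0.34 log units) apart, within the scatter of two such steps

The methyl in place of hydrogen on an amide-type nitrogen, whose step had stayed within the scatter in the tert-butyl pair, now gives a 3.4-fold lower number from compound 2 to compound 4 (0.53 log units; beyond the scatter) in the benzyl pair, yet this difference between the pairs cannot be taken as a real dependence on the neighbouring change: the same change on two cores in this assay, a 1.6-fold lower number (0.19 log units; within the scatter) from compound 1 to compound 3 and a 3.4-fold lower number (0.53 log units; beyond the scatter) from compound 2 to compound 4, 2.2-fold (0.34 log units) apart, within the scatter of two such steps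

Across these four compounds, therefore, the two changes can be read as separate, with no interplay between them established.

The compounds shown leave open how this amide-type nitrogen would respond to a cyclohexyl group, a longer phenethyl chain, or a benzyl group carrying an amine or a carboxylic acid. They also leave open whether an ethyl in place of the methyl would lower the number any further in this series.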